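Swapping a Lactam Chain for a Hydroxy Pyrrolidine Chain

A few compounds are considered here, and "the series" means these few. Any claim that something is new, unique, unknown or untested is made for them only; others in the source may bear on it.

Measured compounds:
compound 1, `COc1cc(OC)c2c(=O)cc(-c3ccc(OCCF)cc3)oc2c1` — "not active" (no number reported)
compound 2, `COc1cc(OC)c2c(=O)cc(-c3ccc(OCCN4CCCC4=O)cc3)oc2c1` — 14%
compound 3, `COc1cc(OC)c2c(=O)cc(-c3ccc(OCCN)cc3)oc2c1` — 35%

In a functional assay (Homo sapiens) for antiproliferative activity, read by resazurin assay, with a stated time of 48 h, tested at 10 uM (on this read-out lower numbers stand for a weaker effect and higher numbers for a stronger effect at the one concentration tested), compound 2 stands lowest of the two numbers recorded: compound 3 sits higher, beyond the scatter, and compound 1 was reported only as not active, without a number. All three share the same core and differ only in the chain attached to the oxygen on the aromatic ring.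

Compound 4, `COc1cc(OC)c2c(=O)cc(-c3ccc(OCC(O)CN4CCCC4)cc3)oc2c1`, has not been measured. Relative to compound 2 the change is 1-hydroxy-2-(pyrrolidin-1-yl)ethyl in place of (2-oxopyrrolidin-1-yl)methyl on a saturated chain carbon bound to an oxygen on an aromatic ring. Going by the values given here, the one measured step that bears on this is a number 21 percentage points higher from compound 2 to compound 3 (beyond the scatter), where the 2-oxopyrrolidin-1-yl group is likewise removed and a nitrogen-containing group remains on the chain. That step was modest and upward. Since compound 4 also loses the 2-oxopyrrolidin-1-yl and keeps a pyrrolidin-1-yl, a rise of similar size is expected in this assay, though the longer chain and the added hydroxy leave room for doubt. Compound 4 is estimated at 30%, ranging from 10% to 55%. The expected step is a number 16 percentage points higher from compound 2 to compound 4 (beyond the scatter).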

Compound 4, a percentage reported as inhibition, at one concentration (the size of the read-out at that concentration, not a potency): 37%
Estimate against measurement, compound 4: 7 percentage points below, and the stated range covers the measured number.
By their numbers in this assay, from the lowest: compound 2; then compounds 3 and 4 (each within the scatter of the next).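

In this assay the 2-hydroxy-3-(pyrrolidin-1-yl)propoxy chain also improves on the 2-(2-oxopyrrolidin-1-yl)ethoxy chain, with a number 23 percentage points higher from compound 2 to compound 4 (beyond the scatter), so the gain seen with the simple amino chain of compound 3 now appears with a second, larger chain that lacks the lactam carbonyl. The two amine-bearing chains cannot be told apart, with a number 2 percentage points higher from compound 3 to compound 4 (within the scatter), which shows that on this saturated chain carbon 1-hydroxy-2-(pyrrolidin-1-yl)ethyl and aminomethyl give a similar reading despite their different size. No measurement shown here accounts for these differences.

Going by these compounds, the hydroxy group and the pyrrolidine ring enter together in compound 4, so their separate contributions remain unknown. A plain 3-(pyrrolidin-1-yl)propoxy chain, or a 2-hydroxy-3-(dimethylamino)propoxy chain, would help to separate them.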